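The source may hold more compounds than are shown below. What is called first, only, known or untested is meant among the compounds shown, and "the series" means these compounds.

Measured so far in an ADME assay on a cell-free system (plasma, Rattus norvegicus) for metabolic stability, read by LC-MS, with a stated time of 60 min, tested at 100 uM; on this read-out higher numbers stand for a more stable compound and lower numbers for a less stable compound:
- compound 1 `Cc1cc(C(=O)O)ccc1OCCCCOc1ccc(C(=O)CC(C)C)c(O)c1C`: 100%
- compound 2 `Cc1cc(C(=O)O)ccc1OCCCCOc1ccc(C(=O)CC2CCCC2)c(O)c1C`: 99%

Compound 1 stands highest of the two numbers in this assay; its nearest neighbour is compound 2, and the step of a number 1 percentage points lower from compound 1 to compound 2 (within the scatter) lies within the scatter, so the two are not distinguished by this read-out. That step is the only one measured, and it changes the group on a saturated chain carbon bound to a carbonyl carbon, which is not the place altered next.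

Compound 3 `Cc1c(OCCCCOc2ccc(F)c(C(=O)O)c2)ccc(C(=O)CC(C)C)c1O` has not yet been measured. It differs from compound 1 as follows: 3-carboxy-4-fluorophenyl in place of 4-carboxy-2-methylphenyl on an oxygen on a saturated carbon

Within the data shown here, no measured step touches the group on the oxygen on the saturated carbon, so nothing measured bears directly on this change. Among the measured compounds shown here, what the two measured compounds show is that the shared core with the tether and the ketone side gives essentially complete recovery in this assay, and the one change tried so far left that unchanged. On that basis compound 3 is expected to show no step beyond the scatter, a number 3 percentage points lower from compound 1 to compound 3 (within the scatter). Compound 3 is therefore estimated at 97%, with a range from 85% to 100%.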

Compound 3, percent of the compound remaining: 101%
Compound 3: the middle estimate sits 4 percentage points below what was measured; measured number outside the range, above it.
By their numbers in this assay, from the lowest: compounds 2, 1 and 3 (each within the scatter of the next).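

Among these compounds, exchanging the group on the oxygen on the saturated carbon, 3-carboxy-4-fluorophenyl in place of 4-carboxy-2-methylphenyl, gives in this assay a number 1 percentage points higher from compound 1 to compound 3 (within the scatter), so this end of the molecule now also has a measured change that leaves the read-out within the scatter, as the one change on the ketone side did. The step replaces one whole substituted phenyl group with another, so the placement of the carboxy group and the exchange of methyl for fluoro are not separated, and neither can be credited with any share of the outcome. Nothing measured gives a reason for this result.

The compounds shown leave open how the two parts of this exchange behave alone, since each compound here carries both substituents of its phenyl group together. Also open, as far as these compounds go, is whether this assay still reads the same when the carboxylic acid gives way to a primary amide or a methyl ester, or when the tether on the oxygen is replaced by a longer chain.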